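From 4-(Trifluoromethyl)phenyl to 2-Fluorophenyl: Expected Cytotoxicity

The source may hold more compounds than are shown below. What is called first, only, known or untested is meant among the compounds shown, and "the series" means these compounds.

Compound 1 `COc1ccc(-c2cc(C)c(Nc3ccnc(Nc4ccc(C#N)cc4)n3)c(C)c2)cc1`: 2890 nM
Compound 2 `Cc1cc(-c2ccc(F)cc2)cc(C)c1Nc1ccnc(Nc2ccc(C#N)cc2)n1`: 4170 nM
Compound 3 `Cc1cc(-c2ccc(C(F)(F)F)cc2)cc(C)c1Nc1ccnc(Nc2ccc(C#N)cc2)n1`: 4160 nM

The three measured compounds were tested in an ADME assay on MT4 cells (Homo sapiens) for cytotoxicity, read by MTT assay, with a stated time of 4 days; on this read-out higher numbers stand for lower toxicity in this test and lower numbers for higher toxicity in this test. Compound 3 gives 4160 nM, a number that sits between the other two, and every gap to a neighbour is within the scatter of repeated measurements: a 1.4-fold higher number from compound 1 to compound 3 (0.16 log units; within the scatter) and a 1.0-fold lower number from compound 2 to compound 3 (0.00 log units; within the scatter). The remaining pair behaves the same way, a 1.4-fold higher number from compound 1 to compound 2 (0.16 log units; within the scatter). So far, then, exchanging the group on the outer ring has not moved the read-out in this assay in any way that can be told from noise.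

Compound 4 `Cc1cc(-c2ccccc2F)cc(C)c1Nc1ccnc(Nc2ccc(C#N)cc2)n1` differs from compound 3 by 2-fluorophenyl in place of 4-(trifluoromethyl)phenyl on an aromatic carbon. Within the data shown here, this change both removes the trifluoromethyl and places a fluoro on the 2-fluorophenyl ring, so none of the measured steps matches it exactly; the closest guides are the three steps above, each within the scatter. On that basis the expected step is a 1.0-fold lower number from compound 3 to compound 4 (0.02 log units; within the scatter), meaning no change beyond the scatter in this assay. Compound 4 is therefore estimated at 4000 nM, with a range from 2000 nM to 8000 nM.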

Compound 4, half-maximal cytotoxic concentration: 2120 nM
Estimate against measurement, compound 4: 1.9-fold (0.28 log units) above; low and high end bracket the measured number.
By their numbers in this assay, from the lowest: compounds 4, 1, 3 and 2 (each within the scatter of the next).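

Keeping the fluoro and changing only its place on the outer ring, with 2-fluorophenyl in place of 4-fluorophenyl, is a kind of change the earlier compounds did not include, and in this assay it gives a 2.0-fold lower number from compound 2 to compound 4 (0.29 log units; within the scatter). The steps from the other two compounds, a 2.0-fold lower number from compound 3 to compound 4 (0.29 log units; within the scatter) and a 1.4-fold lower number from compound 1 to compound 4 (0.13 log units; within the scatter), tell the same story, so this position has now carried four different outer rings without any step that can be told from noise, even though the 2-fluorophenyl ring differs from the others in where its group sits as well as in which group it carries. Nothing measured here bears on the reason for these numbers, and the small differences give little to explain.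

The compounds shown leave open whether a group of a different kind on the outer ring, such as an amine or a carboxylic acid, would give a step beyond the scatter in this assay. As far as these compounds go, it is also open whether 2-methoxyphenyl or 2-(trifluoromethyl)phenyl would read like compound 4 or like their counterparts, compound 1 and compound 3.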